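This account rests on a few compounds, and the source may have more. Where it says the series, first, only, none or still open, it means among the compounds named here.

Among the compounds with values here, compound 2 `CCCC(=O)Nc1cccc(C(=O)/C=C/c2ccc(O)c(OC)c2)c1` gives, in a functional assay on U-87MG ATCC cells (Homo sapiens) for inhibition (on this read-out lower numbers stand for stronger inhibition and higher numbers for weaker inhibition), a value of 5.56 ug/mL, the lowest of the two numbers so far. Within the data shown here, compound 1 `COc1cc(/C=C/C(=O)c2cccc(NC(=O)c3cccs3)c2)ccc1O` is the only neighbour; in this assay compound 1 gives 14.7 ug/mL, and the step of a 2.6-fold lower number from compound 1 to compound 2 (0.42 log units; beyond the scatter) came from a propyl in place of thiophen-2-yl on a carbonyl carbon. Compound 3 `COc1cc(/C=C/C(=O)c2cccc(NC(=O)c3ccc(Cl)cc3Cl)c2)ccc1O` reverses that direction: its change from compound 2 is 2,4-dichlorophenyl in place of propyl on a carbonyl carbon. Among the measured compounds shown here, the one measured step bearing on it shows that a propyl in that place gave a lower number than an aromatic ring; a different aromatic ring now enters, so a modest rise in number beyond the scatter is expected, though the two rings are not the same and the size is uncertain. For compound 3 the expected step is a 2.0-fold higher number from compound 2 to compound 3 (0.30 log units; within the scatter), giving an estimate of 11 ug/mL with a range from 4.5 ug/mL to 28 ug/mL.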

Compound 3, half-maximal inhibitory concentration: > 50 ug/mL
Compound 3: a limit, no number (the forecaster's own chance of this, stated with the estimate: 5%); middle value at least 4.5-fold (0.65 log units) away from the limit.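

At the carbonyl carbon whose other neighbours are the amide-type nitrogen, 2,4-dichlorophenyl yields a limit rather than a number in this assay: the limit of > 50 ug/mL in this assay, at which 1 of the 3 values shown sits.

Putting it in place of propyl gives an at least 8.9-fold higher number from compound 2 to compound 3 (0.95 log units; beyond the scatter), and putting it in place of thiophen-2-yl gives an at least 3.4-fold higher number from compound 1 to compound 3 (0.53 log units; beyond the scatter). The earlier pair had shown only that one aromatic ring, thiophen-2-yl, gave a higher number than propyl; now a second ring gives a higher number than both, and this place separates the three groups by more than that single step had revealed.

Going by these compounds, what a plain phenyl or a longer chain such as pentyl would give at this carbon stays open, and the two chlorine atoms cannot be told apart from the ring that carries them. On these data alone, the full size of both new steps also stays open, as each is bounded on one side only.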